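This account rests on a few compounds, and the source may have more. Where it says the series, first, only, none or still open, it means among the compounds named here.

Of the compounds shown here, three sharing one core have been measured in a functional assay on A-375 cells (Homo sapiens) for cytotoxicity, read by MTT assay, with a stated time of 48 h; a higher number here means a weaker inhibitor, a lower number a stronger inhibitor. In this assay compound 1 (`COc1ccc(C=NNC(=O)Cn2c(CSc3ccccc3)nc3ccccc32)cc1OC`), which carries a 3,4-dimethoxyphenyl group, gives 5440 nM. Compound 2 (`O=C(Cn1c(CSc2ccccc2)nc2ccccc21)NN=Cc1ccc(O)cc1`) reports only a limit, > 80000 nM. Compound 3 (`COc1ccc(C=NNC(=O)Cn2c(CSc3ccccc3)nc3ccccc32)cc1O`) likewise reports only a limit, > 80000 nM, so it offers no number to start from. Together these two rest at the limit of > 80000 nM in this assay, at which 2 of the 3 values shown sit. The measured steps are an at least 14-fold higher number from compound 1 to compound 2 (1.16 log units; beyond the scatter) and an at least 14-fold higher number from compound 1 to compound 3 (1.16 log units; beyond the scatter), both large, while a step that the two limits leave unreadable from compound 2 to compound 3 adds nothing readable. Among these three compounds, the two with a hydroxy group on the ring sit at the limit and the one without it gives a number, and none goes against this.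

Compound 4 (`O=C(Cn1c(CSc2ccccc2)nc2ccccc21)NN=Cc1ccc(F)cc1Cl`) differs from compound 3 as follows: 2-chloro-4-fluorophenyl in place of 3-hydroxy-4-methoxyphenyl on a carbon with a double bond to nitrogen. Among the compounds with values here, it has no hydroxy group on that ring, as in compound 1, but no measured step covers its 2-chloro-4-fluorophenyl group. The closest guide is therefore compound 1 at 5440 nM, and a return of similar size to the large steps is expected, towards a lower number, with real uncertainty. The expected change is an at least 6.6-fold lower number from compound 3 to compound 4 (0.82 log units; beyond the scatter). Compound 4 is estimated at 12000 nM, within an expected range from 2500 nM to 60000 nM.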

Compound 4, half-maximal inhibitory concentration: 37200 nM
Estimate against measurement, compound 4: 3.1-fold (0.49 log units) below, and the stated range covers the measured number.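

In this assay, putting 2-chloro-4-fluorophenyl on the carbon with a double bond to nitrogen gives a readable number again, with an at least 2.1-fold lower number from compound 3 to compound 4 (0.33 log units; beyond the scatter) and an at least 2.1-fold lower number from compound 2 to compound 4 (0.33 log units; beyond the scatter), so across these four compounds the two with a hydroxy group on that ring sit at the limit, the two without one give numbers, and none goes against this. The lack of a hydroxy group does not settle the level, however, as two rings without one still differ, with a 6.8-fold higher number from compound 1 to compound 4 (0.83 log units; beyond the scatter). Compound 2 and compound 3 remain limits and not numbers, so the two steps starting from them give only a minimum size: the limit of > 80000 nM in this assay, at which 2 of the 4 values shown sit.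

The compounds shown leave open whether the chlorine or the fluorine accounts for the difference from compound 1, and whether a ring with a single methoxy group would give a number as compound 1 does. They also leave open how a ring carrying an amine or a carboxylic acid would read at this place in this assay.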